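Changing the benzyl substituent on the shared core

The source may hold more compounds than are shown below. What is called first, only, known or untested is meant among the compounds shown, and "the series" means these compounds.

For the measured compounds named here, compound 1 `CCCn1c(=O)c2nc(-c3cnn(Cc4cc(F)ccc4Cl)c3)[nH]c2n(CCC)c1=O` is the only member of this set with a numeric reading: in an in vitro assay on HEK293 cells for displacement of a labelled ligand from adenosine receptor A2b (Homo sapiens) (a higher number here means a weaker inhibitor, a lower number a stronger inhibitor), compound 1 gives 4800 nM. Compound 2 `CCCn1c(=O)c2c(nc(-n3cc(I)cn3)n2Cc2ccccc2)n(CCC)c1=O` reaches only a limit in this assay, > 5800 nM, which is the limit of > 5800 nM in this assay, at which 1 of the 3 values shown sits. Compound 3 `CCCn1c(=O)c2nc(-c3cnn(-c4ccc(Cl)cc4)c3C(F)(F)F)[nH]c2n(CCC)c1=O` likewise reaches only a limit in this assay, > 6600 nM, which is the limit of > 6600 nM in this assay, at which 1 of the 3 values shown sits. Going by the values given here, no two of these three differ in a single place, so no measured step is available, and compound 1 stands alone as the one number the series has produced.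

Compound 4 `CCCn1c(=O)c2nc(-c3cnn(Cc4ccccc4C)c3)[nH]c2n(CCC)c1=O` differs from compound 1 by 2-methylphenyl in place of 2-chloro-5-fluorophenyl on a saturated chain carbon bound to an aromatic nitrogen. Among the compounds with values here, both the leaving and the entering group are six-membered aromatic rings of carbon only, without hydrogen-bond donors or acceptors, and no measured pair in the set tests this swap. The step from compound 1 to compound 4 is expected to stay within the scatter or to drift slightly toward weaker binding, a 1.4-fold higher number from compound 1 to compound 4 (0.13 log units; within the scatter). Compound 4 is accordingly estimated at 6500 nM, within a range of 2500 nM to 17000 nM, with a real chance that this assay reports only a limit.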

Compound 4, inhibition constant: 33 nM
Compound 4: middle estimate off by 200-fold (2.29 log units), on the high side; the measured number lies below the stated range.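

In this assay, this place on the shared core proves highly sensitive to the aromatic group carried on the saturated chain carbon bound to an aromatic nitrogen: 2-methylphenyl in place of 2-chloro-5-fluorophenyl gives a 150-fold lower number from compound 1 to compound 4 (2.16 log units; beyond the scatter), a large step. The earlier compounds shown here offered one number and two limits, with no pair differing in one place, so they gave no reading of this position. Nothing shown accounts for the size of this step.

For the compounds shown here, the single pair cannot separate the loss of the chlorine and fluorine from the gain of the methyl, so the contribution of each stays open. On these data alone, how a 2-chlorobenzyl, a 2-methoxybenzyl or a pyridylmethyl group would read at this place in this assay also remains open.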